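Head-group change from compound 3 to compound 4

The source may report more compounds than this note shows. Statements on the series, on what has been measured and on what is new or still open speak of the compounds shown alone.

Compound 3 `CCCCCCCCCCc1ccc(-c2noc(-c3cccc(CN)c3)n2)cc1` gives 2% in an assay on HeLa cells for inhibition of sphingosine-1-phosphate transporter SPNS2 (Mus musculus), read by LC-MS, tested at 2 uM (on this read-out higher numbers stand for more inhibition at the one concentration tested (going by the name of the read-out) and lower numbers for less inhibition), the lowest of the three numbers in hand. Compound 1 `CCCCCCCCCCc1ccc(-c2noc(CC3CCNC3)n2)cc1` gives 44% in this assay, and compound 2 `CCCCCCCCCCc1ccc(-c2noc([C@@H]3CCCN3)n2)cc1` gives 21%. Both steps into compound 3 are beyond the scatter: a number 42 percentage points lower from compound 1 to compound 3 (beyond the scatter) and a number 19 percentage points lower from compound 2 to compound 3 (beyond the scatter). Between the two ring-bearing amines, a number 23 percentage points lower from compound 1 to compound 2 (beyond the scatter).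

Compound 4 `CCCCCCCCCCc1ccc(-c2noc([C@@H](N)CCCCN)n2)cc1` is not yet measured. Its change from compound 3 is 1,5-diaminopentyl in place of 3-(aminomethyl)phenyl on an aromatic carbon

For the measured compounds named here, the steps that bear on this change are the two steps into compound 3, each a loss when 3-(aminomethyl)phenyl replaced a group carrying an aliphatic ring amine. Going by the values given here, compound 4 moves in the opposite sense, away from 3-(aminomethyl)phenyl and toward an aliphatic, open-chain group with two amines; no measured step covers 1,5-diaminopentyl itself, so the size is uncertain. An upward step in this assay beyond the scatter is expected, on the order of a number 28 percentage points higher from compound 3 to compound 4 (beyond the scatter), drawing on the losses seen in a number 42 percentage points lower from compound 1 to compound 3 (beyond the scatter) and a number 19 percentage points lower from compound 2 to compound 3 (beyond the scatter). Compound 4 is therefore estimated at 30%, with an expected range from 5% to 60%.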

Compound 4, a percentage reported as inhibition, at one concentration (the size of the read-out at that concentration, not a potency): 43%
Compound 4: middle estimate off by 13 percentage points, on the low side; measured number inside the range.
By their numbers in this assay, from the lowest: compound 3; then compound 2; then compounds 4 and 1 (each within the scatter of the next).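

At this position a group with no ring holds up in this assay: 1,5-diaminopentyl in place of 3-(aminomethyl)phenyl gives a number 41 percentage points higher from compound 3 to compound 4 (beyond the scatter) and so recovers nearly all of the loss seen with the aromatic group, which shows that a ring in the group at this carbon is not needed to reach the level of compound 1. Set against the earlier aliphatic amines, the same open chain gives a number 22 percentage points higher from compound 2 to compound 4 (beyond the scatter) from the pyrrolidin-2-yl group, while a number 1 percentage points lower from compound 1 to compound 4 (within the scatter) means that 1,5-diaminopentyl and (pyrrolidin-3-yl)methyl cannot be told apart on this read-out. Nothing in hand accounts for any of these steps.

The compounds shown do not separate the contributions of the two amines of 1,5-diaminopentyl, so a chain with one amine only, or a carboxylic acid in place of one amine, would be the informative comparison. Also open, from the compounds shown here alone, are the effect of a longer diamine chain and of the opposite configuration at the defined stereocentre, and how any of these groups behaves at concentrations other than the single one tested.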